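This account rests on a few compounds, and the source may have more. Where it says the series, first, only, none or still open, it means among the compounds named here.

Measured compounds:
Compound 1 `Nc1ccccc1NC(=O)c1ccc(CSC(=S)N2CCN(C(c3ccccc3)c3ccccc3)CC2)cc1` — in a functional assay on MGC-803 cells (Homo sapiens) for antiproliferative activity, read by CCK-8 assay, with a stated time of 72 h, tested at 2 uM (a lower number here means a weaker effect, a higher number a stronger effect of the compound at the concentration tested), compound 1 gives 9.8%
Compound 2 `COc1ccc(N2CCN(C(=S)SCc3ccc(C(=O)Nc4ccccc4N)cc3)CC2)cc1` — compound 2 gives 25.3%
Compound 3 `CC1CCCCN1C(=S)SCc1ccc(C(=O)Nc2ccccc2N)cc1` — compound 3 gives 64.4%

Three compounds share one core and differ only in the group on the sulfur-bearing end. Compound 2 stands second highest of the three in this assay: its number is beyond the scatter above that of compound 1 and beyond the scatter below that of compound 3. Compound 4 `Nc1ccccc1NC(=O)c1ccc(CSC(=S)N2CCN(c3ccccc3F)CC2)cc1` is not yet measured. It differs from compound 2 in one place (2-fluorophenyl in place of 4-methoxyphenyl on an amine nitrogen in a ring). Going by the values given here, no pair of measured compounds differs in one place only, so no measured step guides this change. Both rings on that nitrogen are aromatic six-membered rings of carbon, so the step from compound 2 to compound 4 is expected to be small and within the scatter, with a number 0.7 percentage points higher from compound 2 to compound 4 (within the scatter) estimated. Compound 4 is therefore expected to give about 26%, likely between 10% and 45%.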

Compound 4, a percentage reported as inhibition, at one concentration (the size of the read-out at that concentration, not a potency): 33.7%
Estimate against measurement, compound 4: 7.7 percentage points below, and the stated range covers the measured number.
By their numbers in this assay, from the lowest: compound 1; then compounds 2 and 4 (each within the scatter of the next); then compound 3.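

In this assay, going by these compounds alone, the first measured step at this position is a number 8.4 percentage points higher from compound 2 to compound 4 (within the scatter) with 2-fluorophenyl in place of 4-methoxyphenyl on the amine nitrogen in the ring. This exchange of one substituted phenyl group for another therefore leaves the two compounds indistinguishable here, even though the substituent and its place on the phenyl ring both differ. No measurement shown offers a reason for this result.

From the compounds shown here alone, whether a group of another kind on this nitrogen, such as a methyl group or a longer carbon chain, would give a clearly different number remains open.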